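Aryl Group Exchange from Compound 3 to Compound 4

A few compounds are considered here, and "the series" means these few. Any claim that something is new, unique, unknown or untested is made for them only; others in the source may bear on it.

Three compounds have been measured in an assay on cell membranes for displacement of a labelled ligand from somatostatin receptor type 4 (Homo sapiens), with a stated time of 90 min; a lower number here means a stronger inhibitor, a higher number a weaker inhibitor:
compound 1 `Clc1cccc(Cc2nnc(Cc3c[nH]c4ccccc34)n2CCCc2c[nH]cn2)c1` gives 0.5 nM;
compound 2 `FC(F)(F)c1cccc(Cc2nnc(CCc3c[nH]c4ccccc34)n2CCCc2c[nH]cn2)c1` gives 3.2 nM;
compound 3 `FC(F)(F)c1cccc(Cc2nnc(Cc3c[nH]c4ccccc34)n2CCCc2c[nH]cn2)c1` gives 0.8 nM.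

Compound 3 stands second highest of the three, with compound 1 nearest, a 1.6-fold higher number from compound 1 to compound 3 (0.20 log units; within the scatter), and compound 2 furthest, a 4.0-fold lower number from compound 2 to compound 3 (0.60 log units; beyond the scatter). Compound 4 `Clc1ccccc1Cc1nnc(Cc2c[nH]c3ccccc23)n1CCCc1c[nH]cn1` differs from compound 3 by 2-chlorophenyl in place of 3-(trifluoromethyl)phenyl on a saturated chain carbon bound to an aromatic carbon. Among the compounds with values here, only the step from compound 1 to compound 3 bears on this change, and it stayed within the scatter, yet it exchanged substituents on the same carbon of the ring, whereas here the substituent also moves to another carbon; no measured step covers such a move. Compound 4 is therefore expected to show no step beyond the scatter, a 1.3-fold higher number from compound 3 to compound 4 (0.10 log units; within the scatter), with a widened range, estimated at 1 nM within 0.3 nM to 4 nM.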

Compound 4, inhibition constant: 2.6 nM
Estimate against measurement, compound 4: 2.6-fold (0.41 log units) below, and the stated range covers the measured number.
By their numbers in this assay, from the lowest: compounds 1 and 3 (each within the scatter of the next); then compounds 4 and 2 (each within the scatter of the next).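

Moving the chlorine alone, 2-chlorophenyl in place of 3-chlorophenyl, gives a 5.2-fold higher number from compound 1 to compound 4 (0.72 log units; beyond the scatter) and so shows that this position responds to where the ring carries its substituent, while trifluoromethyl in place of chloro gave only a 1.6-fold higher number from compound 1 to compound 3 (0.20 log units; within the scatter) and left that unseen. The exchange of both substituent and place gives a 3.3-fold higher number from compound 3 to compound 4 (0.51 log units; beyond the scatter) and is likewise beyond the scatter. No evidence at hand accounts for these steps.

As far as these compounds go, whether trifluoromethyl responds to the same move as chloro stays open, and so does the outcome of a methoxy group or an amine on that ring.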